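The source may hold more compounds than are shown below. What is called first, only, known or untested is meant among the compounds shown, and "the series" means these compounds.

Compound 1 `S=C(NCc1ccccc1)Nc1ccc2c(c1)OCCO2` in a functional assay on RAW264.7 cells (Mus musculus) for inhibition, read by Griess assay, with a stated time of 24 h (on this read-out higher numbers stand for weaker inhibition and lower numbers for stronger inhibition), gives 13700 nM.
Compound 2 `S=C(Nc1ccccc1)N1CCN(c2ncccn2)CC1` gives only a limit of this assay, >= 200000 nM.
Compound 3 `S=C(NCc1ccccc1)N1CCN(c2ncccn2)CC1` likewise gives only a limit of this assay, >= 200000 nM.

Compound 3 therefore stands at the edge of what this assay can report: no number is known for it, only (the limit of >= 200000 nM in this assay, at which 2 of the 3 values shown sit). Going by the values given here, the single measured step, a step that the two limits leave unreadable from compound 2 to compound 3, runs between two such limits, so its size cannot be read. Compound 4 `O=C(C1CCCO1)N1CCN(C(=S)NCc2ccccc2)CC1` keeps the core of compound 3 and differs from it in one place: (oxolan-2-yl)carbonyl in place of pyrimidin-2-yl on an amine nitrogen in a ring. Among the compounds with values here, no measured step involves this exchange, and the one step that was measured concerns a different part of the molecule, so it gives no guide to the direction or size of the change. With compound 3 at the limit, the expectation for compound 4 can only rest on that starting point and is kept wide. Compound 4 is expected to give about 120000 nM, with a range from 25000 nM to 200000 nM. That estimate means an expected step of an at least 1.6-fold lower number from compound 3 to compound 4 (0.22 log units; that floor lies within the scatter), and a further limit rather than a number is thought quite possible.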

Compound 4, half-maximal inhibitory concentration: >= 200000 nM
Compound 4 ended at the assay's limit; the forecaster's own chance of this, stated with the estimate: 55%; at least 1.6-fold (0.22 log units) between middle value and limit.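

Compound 3 and compound 4 both give only a limit in this assay, not a number, so the step between them cannot be read: the limit of >= 200000 nM in this assay, at which 3 of the 4 values shown sit.

Going by these compounds, whether putting (oxolan-2-yl)carbonyl in place of pyrimidin-2-yl changes inhibition at all, and in which direction, stays open.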